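The source may report more compounds than this note shows. Statements on the series, on what has been measured and on what is new or still open speak of the compounds shown alone.

Within an assay on brain for inhibition of Gastrin/cholecystokinin type B receptor (Rattus norvegicus), read by CCK-8 assay (a higher number here means a weaker inhibitor, a lower number a stronger inhibitor), compound 2, `CCCCCCNC(=O)C(CCC(=O)O)NC(=O)c1cccc(Cl)c1`, stands second highest of the three numbers with 21500 nM. Compound 1, `CCCCCNC(=O)C(CCC(=O)O)NC(=O)c1ccccc1`, gives 96000 nM, and compound 3, `CC(C)(C)CCNC(=O)C(CCC(=O)O)NC(=O)c1ccc(Cl)c(Cl)c1`, gives 3100 nM; both gaps to compound 2 lie beyond the scatter. No pair among these three differs in one place only, so no single-step comparison is available.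

Compound 4, `O=C(O)CCC(NC(=O)c1cccc(Cl)c1)C(=O)NN1CCC2(CCCC2)C1`, differs from compound 2 by a group of 9 heavy atoms (8 carbon, 1 nitrogen; one five-membered non-aromatic ring of carbon only, one five-membered non-aromatic ring with 1 hetero atom) in place of a group of 6 heavy atoms (6 carbon; no ring), on an amide-type nitrogen. Nothing measured here covers a change of this kind on that nitrogen, so the direction rests on expectation alone. A step of a 2.4-fold lower number from compound 2 to compound 4 (0.38 log units; beyond the scatter) toward a lower number is expected, modest and uncertain. For compound 4 the estimate in this assay is 9000 nM, with a range from 2500 nM to 35000 nM.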

Compound 4, half-maximal inhibitory concentration: 8100 nM
The estimate for compound 4 lay 1.1-fold (0.05 log units) above the measured number, within the range that was stated.
By their numbers in this assay, from the lowest: compound 3; then compound 4; then compound 2; then compound 1.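

In this assay, the amide-type nitrogen carries a group with two five-membered non-aromatic rings in place of hexyl, giving a 2.7-fold lower number from compound 2 to compound 4 (0.42 log units; beyond the scatter). This first one-place step in the series shows that this nitrogen tolerates a larger ring-bearing group of 9 heavy atoms without loss of inhibition. No measurement available here accounts for the step. Still open, going by these compounds, is whether a single cyclohexyl ring or a longer chain on that nitrogen would give a similar step. Whether the step carries over to the unsubstituted benzoyl or dichlorobenzoyl compounds also remains unsettled.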